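Four Aryl Variants on One Core Against Prostate Cells

This account rests on a few compounds, and the source may have more. Where it says the series, first, only, none or still open, it means among the compounds named here.

Of the compounds shown here, three that share one core have been tested in a functional assay on LNCaP cells (Prostate gland, Homo sapiens) for antiproliferative activity, read by sulforhodamine B assay; on this read-out higher numbers stand for weaker inhibition and lower numbers for stronger inhibition. Compound 1 `CCCCCCCCCCCCCCCCCCNC(=O)[C@H]1CSC(c2c[nH]c3ccccc23)N1` gives 2100 nM in this assay. Compound 2 `CCCCCCCCCCCCCCCCCCNC(=O)[C@H]1CSC(c2ccc(N(C)C)cc2)N1` gives 1600 nM there, and compound 3 `CCCCCCCCCCCCCCCCCCNC(=O)[C@H]1CSC(c2cccc(O)c2)N1` gives 1700 nM. The three numbers are close together: a 1.3-fold lower number from compound 1 to compound 2 (0.12 log units; within the scatter), a 1.2-fold lower number from compound 1 to compound 3 (0.09 log units; within the scatter) and a 1.1-fold higher number from compound 2 to compound 3 (0.03 log units; within the scatter) all lie inside the scatter of repeated measurements. Compound 3 thus has the middle number of the three, its gap to compound 2 being the smaller and its gap to compound 1 the larger, and neither gap exceeds the scatter.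

Compound 4 `CCCCCCCCCCCCCCCCCCNC(=O)[C@H]1CSC(c2ccc(F)cc2)N1` differs from compound 3 in one place: 4-fluorophenyl in place of 3-hydroxyphenyl on a saturated ring carbon. For the measured compounds named here, every measured step so far is a change of the group on that same saturated ring carbon, and none of them moved the number beyond the scatter, so the data give no reason to expect a different outcome for a fourth group at the same place. For compound 4 the estimated step of no change at the digits printed from compound 3 to compound 4 (within the scatter) is therefore expected to stay within the scatter. On that basis compound 4 is estimated at 1700 nM in this assay, with a likely range from 800 nM to 3600 nM.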

Compound 4, half-maximal inhibitory concentration: 1900 nM
Estimate against measurement, compound 4: 1.1-fold (0.05 log units) below; the range from low to high includes it.
By their numbers in this assay, from the lowest: compounds 2, 3, 4 and 1 (each within the scatter of the next).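

For the compounds shown here, with compound 4, a fluorine-bearing aryl group stands on the saturated ring carbon for the first time, and in this assay the exchange gives a 1.1-fold higher number from compound 3 to compound 4 (0.05 log units; within the scatter). The 4-fluorophenyl group counts no hydrogen-bond donors or acceptors where 3-hydroxyphenyl counts one of each, yet this change in the counts goes with a step inside the scatter, and the swap of fluoro for dimethylamino on the aromatic carbon, a 1.2-fold higher number from compound 2 to compound 4 (0.07 log units; within the scatter), and the replacement of the two-ring 1H-indol-3-yl group, a 1.1-fold lower number from compound 1 to compound 4 (0.04 log units; within the scatter), stay inside it too, so all four aryl groups at this position are indistinguishable on this read-out. No measurement available here speaks to why the steps at this position are so small.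

The compounds shown leave open whether a carboxylic acid or a primary amine on the aromatic ring, or a cyclohexyl group in place of the aryl group, would move the number beyond the scatter at this carbon. From the compounds shown here alone, the long chain on the amide is the same in all four compounds, so what a shorter chain would do to the number also remains open.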